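The source may hold more compounds than are shown below. What is called first, only, known or untested is meant among the compounds shown, and "the series" means these compounds.

Compound 1 `COc1nn2cc(-c3cc4ccccc4o3)nc2s1` and compound 2 `CCOc1nn2cc(-c3cc4ccccc4o3)nc2s1` share one core and differ only in the chain on the ring oxygen. Among the compounds with values here, in an assay for antagonist activity at proteinase-activated receptor 4 (Homo sapiens), with stated times of 5 min, 50 s and 15 min, in the presence of a further agent that is not named here (on this read-out lower numbers stand for stronger inhibition and higher numbers for weaker inhibition), compound 1 gives 240 nM, and compound 2 gives 2100 nM, the higher of the two numbers measured so far, so compound 2 is the weaker of the pair; the step of an 8.8-fold higher number from compound 1 to compound 2 (0.94 log units; beyond the scatter) lies beyond the scatter. Compound 3 `CC(C)Oc1nn2cc(-c3cc4ccccc4o3)nc2s1` has not yet been measured. It differs from compound 2 by methyl in place of hydrogen on a saturated chain carbon bound to an oxygen on an aromatic ring and a saturated chain carbon, the same kind of change as the one between the two measured compounds, only one bond further out. Within the data shown here, the single step that bears on it, an 8.8-fold higher number from compound 1 to compound 2 (0.94 log units; beyond the scatter), ran to a weaker number, so a further rise in this assay is expected, though it may be smaller. The expected step is a 2.9-fold higher number from compound 2 to compound 3 (0.46 log units; beyond the scatter), which gives compound 3 an estimated value of 6000 nM, with a range from 2000 nM to 20000 nM.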

Compound 3, half-maximal inhibitory concentration: > 30000 nM
Compound 3: no number, only a limit (the forecaster's own chance of this, stated with the estimate: 20%); middle value at least 5.0-fold (0.69 log units) from the limit.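

Compound 3 gives no exact number in this assay, only a limit of the assay: the limit of > 30000 nM in this assay, at which 1 of the 3 values shown sits. Even so, the change from ethoxy to isopropoxy gives an at least 14-fold higher number from compound 2 to compound 3 (1.15 log units; beyond the scatter), which shows that a second methyl added at this carbon still weakens inhibition, so the loss seen with the first added methyl does not level off here. Taken across the whole series, isopropyl in place of methyl on the oxygen gives an at least 120-fold higher number from compound 1 to compound 3 (2.09 log units; beyond the scatter), and in these three compounds, with none going against it, the smallest chain, methyl, gives the strongest inhibition.

As far as these compounds go, the true size of the last step stays open, since the limit gives only its smallest possible size. Also open, from the compounds shown here alone, is whether a straight propyl chain on this oxygen would lose as much as isopropyl, and what an amine or a carboxylic acid on the chain would do.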